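From 4-Methylpiperazin-1-yl to 4-Ethylpiperazin-1-yl in a Cytotoxicity Series

This account rests on a few compounds, and the source may have more. Where it says the series, first, only, none or still open, it means among the compounds named here.

Of the compounds shown here, three sharing one core have been measured in a functional assay on U-937 cells (Homo sapiens) for cytotoxicity, read by MTT assay and WST assay, with a stated time of 72 h; on this read-out lower numbers stand for stronger inhibition and higher numbers for weaker inhibition. Compound 1 `Cc1nc(Nc2ccc3sc(C(=O)Nc4c(C)cccc4Cl)cc3c2)cc(N2CCCCC2)n1` gives 20000 nM. Compound 2 `Cc1nc(Nc2ccc3sc(C(=O)Nc4c(C)cccc4Cl)cc3c2)cc(N2CCC(C)CC2)n1` gives 20600 nM, and compound 3 `Cc1nc(Nc2ccc3sc(C(=O)Nc4c(C)cccc4Cl)cc3c2)cc(N2CCN(C)CC2)n1` gives 15000 nM. The three numbers lie close together: a 1.3-fold lower number from compound 1 to compound 3 (0.12 log units; within the scatter), and a 1.4-fold lower number from compound 2 to compound 3 (0.14 log units; within the scatter), so compound 3 is not separated from either neighbour by more than the usual scatter, and no ordering among the three can be claimed.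

Compound 4 `CCN1CCN(c2cc(Nc3ccc4sc(C(=O)Nc5c(C)cccc5Cl)cc4c3)nc(C)n2)CC1` differs from compound 3 in one place: methyl in place of hydrogen on a saturated chain carbon bound to an amine nitrogen in a ring. Within the data shown here, the measured step that bears most directly on this change is the one from compound 1 to compound 2, where a methyl likewise replaced a hydrogen on a saturated ring carbon: a 1.0-fold higher number from compound 1 to compound 2 (0.01 log units; within the scatter). That earlier methyl addition left the number essentially unchanged, and the swap of the whole ring between compound 2 and compound 3 also moved the number only within the scatter. Nothing in the series therefore points to a shift beyond the scatter in this assay when the 4-methylpiperazin-1-yl becomes 4-ethylpiperazin-1-yl.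

Compound 4 is accordingly expected to give about 15000 nM, within a range of 7500 nM to 30000 nM. The step from compound 3 is estimated as no change at the digits printed from compound 3 to compound 4 (within the scatter), a change not expected to exceed the scatter.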

Compound 4, half-maximal inhibitory concentration: 13100 nM
Beside the measured number, compound 4's estimate is 1.1-fold (0.06 log units) above it, and the stated range covers the measured number.
By their numbers in this assay, from the lowest: compounds 4, 3, 1 and 2 (each within the scatter of the next).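

In this assay a 1.1-fold lower number from compound 3 to compound 4 (0.06 log units; within the scatter) shows that this position, a saturated chain carbon bound to an amine nitrogen in a ring, tolerates an added methyl without a shift beyond the scatter, a place that the earlier methyl step on a saturated ring carbon did not probe. Turning 4-methylpiperazin-1-yl into 4-ethylpiperazin-1-yl also leaves compound 4 within the scatter of both piperidine-bearing compounds, with a 1.6-fold lower number from compound 2 to compound 4 (0.20 log units; within the scatter) and a 1.5-fold lower number from compound 1 to compound 4 (0.18 log units; within the scatter) as the two remaining steps, so all the ring and substituent changes shown so far stay inside the scatter in this assay and none separates one compound from another. Nothing shown here gives an independent measurement that would explain why these numbers sit so close together.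

The compounds shown leave open whether a longer chain such as propyl, or a chain ending in a hydroxyl group or a carboxylic acid, on the same piperazine nitrogen would move the number beyond the scatter. Among these compounds, they also leave open whether replacing the piperazine with a morpholine or an open-chain amine would do so, as every step so far lies within the scatter.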